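Chloro substitution on the aryl ketone in a kynurenine monooxygenase series

A few compounds are considered here, and "the series" means these few. Any claim that something is new, unique, unknown or untested is made for them only; others in the source may bear on it.

Measured so far:
compound 1 `COC(=O)C(=N)/C=C(\O)c1ccc(Br)cc1`: 0%
compound 2 `N/C(=C\C(=O)c1ccccc1)C(=O)O`: 17%

In an assay for inhibition of kynurenine 3-monooxygenase (Rattus norvegicus), tested at 10 uM (on this read-out lower numbers stand for less inhibition and higher numbers for more inhibition at the one concentration tested (going by the name of the read-out)), compound 2 gives 17%, the higher of the two numbers recorded. Its nearest neighbour is compound 1, which in this assay gives 0%, a gap that lies beyond the usual scatter of the read-out. Among the compounds with values here, the two structures differ in several places at once, so no single step can be drawn between them; only the two values themselves are known.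

Compound 3 `N/C(=C\C(=O)c1ccccc1Cl)C(=O)O` is the next candidate. Relative to compound 2 the change is chloro in place of hydrogen on an aromatic carbon. Without a comparable step among the measured pairs, the expected change is small and could fall within the scatter in either direction.

For compound 3 in this assay the estimate is 20%, with a range from 3% to 45%. This estimate means a step of a number 3 percentage points higher from compound 2 to compound 3 (within the scatter), expected to stay within the scatter.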

Compound 3, a percentage reported as inhibition, at one concentration (the size of the read-out at that concentration, not a potency): 19%
Estimate against measurement, compound 3: 1 percentage points above, and the stated range covers the measured number.
By their numbers in this assay, from the lowest: compound 1; then compounds 2 and 3 (each within the scatter of the next).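

Chloro in place of hydrogen on an aromatic carbon, ortho to a group of 8 heavy atoms, gives in this assay a step of a number 2 percentage points higher from compound 2 to compound 3 (within the scatter) and is the first single-place change available in this series. The earlier compounds shown here offered no such pair, and this one shows that a single chlorine atom at this position of the six-membered aromatic ring leaves the read-out within the scatter. The step comes from one pair at one concentration, so it describes this position and this substituent only and gives no potency. No evidence at hand bears on why the step has this size.

Still open, on these data alone, is whether a larger or different group at the same place, such as methoxy, an amine or a longer chain, would move the read-out beyond the scatter. As far as these compounds go, the effect of chloro on the other carbons of this ring also remains unknown.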